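The source may report more compounds than this note shows. Statements on the series, on what has been measured and on what is new or still open speak of the compounds shown alone.

Measured so far in a functional assay on TK-10 cells (Homo sapiens) for inhibition, read by sulforhodamine B assay, with a stated time of 48 h; a lower number here means that less compound is tolerated, a higher number that more compound is tolerated:
compound 1 `O=C(Nc1cccc(-n2cc(-c3ccncc3)c(-c3ccc(Cl)c(O)c3)n2)c1)Nc1cccc(C(F)(F)F)c1`, > 32500 nM (a limit, not a number)
compound 2 `COc1cc(-c2nn(-c3cccc(NC(=O)Nc4cc(C(F)(F)F)cc(C(F)(F)F)c4)c3)cc2-c2ccncc2)ccc1Cl`, 10100 nM
compound 3 `COc1cc(-c2nn(-c3cccc(NC(=O)Nc4cccc(C(F)(F)F)c4)c3)cc2-c2ccncc2)ccc1Cl`, > 50000 nM (a limit, not a number)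

For the measured compounds named here, compound 2 holds the only real number in this assay; the other two values are limits. Compound 1 sits at a limit, (the limit of > 32500 nM in this assay, at which 1 of the 3 values shown sits). Compound 3 likewise sits at a limit, (the limit of > 50000 nM in this assay, at which 1 of the 3 values shown sits). The step that the two limits leave unreadable from compound 1 to compound 3 is therefore not readable, although it is the same change as the one considered here, run the other way. The step of an at least 4.9-fold higher number from compound 2 to compound 3 (0.69 log units; beyond the scatter) concerns a different position and does not touch the oxygen.

Compound 4 `O=C(Nc1cccc(-n2cc(-c3ccncc3)c(-c3ccc(Cl)c(O)c3)n2)c1)Nc1cc(C(F)(F)F)cc(C(F)(F)F)c1` keeps both trifluoromethyl groups of compound 2 and differs from it only by hydrogen in place of methyl on an oxygen on an aromatic ring. No readable measured step covers this change, so the expectation for compound 4 rests on compound 2 alone, with a wide range: an estimated 12000 nM (4000 nM to 40000 nM), which means an expected step of a 1.2-fold higher number from compound 2 to compound 4 (0.07 log units; within the scatter), with a fair chance that the assay returns only a limit.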

Compound 4, concentration lethal to 50% of the cells: 14200 nM
Beside the measured number, compound 4's estimate is 1.2-fold (0.07 log units) below it; the range from low to high includes it.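

In this assay the step of a 1.4-fold higher number from compound 2 to compound 4 (0.15 log units; within the scatter) gives the first readable measure of methoxy to hydroxy on an oxygen on an aromatic ring, and on this core with two trifluoromethyl groups the two compounds are not told apart. The step of an at least 2.2-fold lower number from compound 1 to compound 4 (0.35 log units; beyond the scatter) shows that trifluoromethyl in place of hydrogen on an aromatic carbon also moves the number among the hydroxy compounds. That change now stands on two cores, though its sizes cannot be compared: the same change on two cores in this assay, an at least 4.9-fold higher number (0.69 log units; beyond the scatter) from compound 2 to compound 3 and an at least 2.2-fold higher number (0.35 log units; beyond the scatter) from compound 4 to compound 1; the limit leaves it open whether they differ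

Going by these compounds, whether methoxy and hydroxy also match with a single trifluoromethyl group stays open: compound 1 and compound 3 both sit at limits, and the step between them cannot be read. Also open, on these data alone, is what this assay returns for an ethyl group or a longer chain on that oxygen, or for an amine in place of the hydroxy.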